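Chloro for nitro on the aryl ring, second pair

The compounds below may be only part of what the source reports. "The series", "measured", "known", "first", "only" and "open" are said of these compounds alone.

Of the compounds shown here, three in this set have been measured in a functional assay on HEK293 cells for antagonist activity at metabotropic glutamate receptor 5 (Rattus norvegicus), read by calcium flux; on this read-out higher numbers stand for weaker inhibition and lower numbers for stronger inhibition. Compound 1 `Cc1cccc(C#Cc2cc(C#N)cc([N+](=O)[O-])c2)n1` gives 3.68 nM. Compound 2 `Cc1cccc(C#Cc2cc(Cl)cc(C#N)c2)n1` gives 1.22 nM. Compound 3 `Cc1ccc(C#Cc2cc(C#N)cc([N+](=O)[O-])c2)nc1` gives 2.64 nM. Compound 4 `Cc1ccc(C#Cc2cc(Cl)cc(C#N)c2)nc1` has not yet been measured.

Compounds 1 and 2 differ in one place: chloro in place of nitro on an aromatic carbon. This change gave a 3.0-fold lower number from compound 1 to compound 2 (0.48 log units; beyond the scatter). Compound 3 differs from compound 1 in the core; the two have the same atoms joined differently, and the difference between the two cores is not broken down here. Compound 3 and compound 1 lie within the scatter of each other, so nothing can be said about their order; compound 3 stands beyond the scatter of compound 2.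

Compound 4 carries the same change relative to compound 3: chloro in place of nitro on an aromatic carbon. The place line of this change matches that of the change from compound 1 to compound 2 word for word, so it is the same change on a different core.

Since the change from compound 1 to compound 2 gave a 3.0-fold lower number from compound 1 to compound 2 (0.48 log units; beyond the scatter), and compound 3 sits close to compound 1, a step of similar size is expected on the second core, with some allowance for the step being smaller. The expected step is a 2.6-fold lower number from compound 3 to compound 4 (0.42 log units; beyond the scatter). Compound 4 is estimated at 1 nM in this assay, with a range from 0.4 nM to 2.5 nM.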

Compound 4, half-maximal inhibitory concentration: 1.22 nM
The estimate for compound 4 lay 1.2-fold (0.09 log units) below the measured number, within the range that was stated.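

Chloro in place of nitro on an aromatic carbon gives a 2.2-fold lower number from compound 3 to compound 4 (0.34 log units; beyond the scatter) in this assay, so on the core of compound 3 the change runs in the same direction as on the core of compound 1, and on both cores the step lies beyond the scatter. The two steps cannot be told apart in size, and within this pair of cores the change carries over as a near-constant step: the same change on two cores in this assay, a 3.0-fold lower number (0.48 log units; beyond the scatter) from compound 1 to compound 2 and a 2.2-fold lower number (0.34 log units; beyond the scatter) from compound 3 to compound 4, 1.4-fold (0.14 log units) apart, within the scatter of two such steps This rests on two cores and one pair of groups, always meta to a cyano group, so it does not show that the step would hold on a further core or with another group in that place, and the numbers give no reason for the step.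

Open, as far as these compounds go, is how a methoxy group, an amine or a carboxylic acid on the same aromatic carbon would compare with chloro and nitro in this assay. Also open is whether the step survives when the cyano group gives way to another group such as trifluoromethyl, since all four compounds shown carry the cyano group.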